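Chlorine-bearing four-membered ring group in place of compound 3's

A few compounds are considered here, and "the series" means these few. Any claim that something is new, unique, unknown or untested is made for them only; others in the source may bear on it.

- compound 1 `c1ccc2c(c1)CC2CCCN1CCN(c2cccc3c2OCCO3)CC1`: 0.18 mg/kg
- compound 2 `c1ccc2c(c1)CC(CCN1CCN(c3cccc4c3OCCO4)CC1)C2`: 0.27 mg/kg
- compound 3 `C1=C(CCN2CCN(c3cccc4c3OCCO4)CC2)Cc2ccccc21`: 0.36 mg/kg

In a functional assay on the whole organism for antagonist activity, with Rattus norvegicus as the target (a lower number here means that less compound is needed, a higher number that more compound is needed for the effect), compound 3 gives 0.36 mg/kg, within the scatter of both other measured compounds: a 2.0-fold higher number from compound 1 to compound 3 (0.30 log units; within the scatter) and a 1.3-fold higher number from compound 2 to compound 3 (0.12 log units; within the scatter). The remaining measured step, a 1.5-fold higher number from compound 1 to compound 2 (0.18 log units; within the scatter), is also within the scatter.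

Compound 4 `Clc1cccc2c1CC2CCN1CCN(c2cccc3c2OCCO3)CC1` differs from compound 3 as follows: a group of 9 heavy atoms (8 carbon, 1 chlorine; one four-membered non-aromatic ring of carbon only, one six-membered aromatic ring of carbon only) in place of a group of 9 heavy atoms (9 carbon; one five-membered non-aromatic ring of carbon only, one six-membered aromatic ring of carbon only), on a saturated chain carbon, two bonds along the chain from an amine nitrogen in a ring. The closest evidence is a 2.0-fold higher number from compound 1 to compound 3 (0.30 log units; within the scatter), which links a four-membered and a five-membered ring group and, read in reverse, runs the same way as the new change. For the measured compounds named here, no measured compound carries chlorine, so that part of the change has no measured step behind it. No step beyond the scatter is therefore expected in this assay, though the chlorine leaves the estimate wide. The expected step is a 1.2-fold lower number from compound 3 to compound 4 (0.08 log units; within the scatter). The estimate for compound 4 is 0.3 mg/kg, with an expected range from 0.1 mg/kg to 0.9 mg/kg.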

Compound 4, dose for 50% inhibition: 1.13 mg/kg
Beside the measured number, compound 4's estimate is 3.8-fold (0.58 log units) below it; measured number above the stated range.
By their numbers in this assay, from the lowest: compounds 1, 2 and 3 (each within the scatter of the next); then compound 4.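

In this assay, for the compounds shown here, the chlorine-bearing four-membered ring group at this saturated chain carbon gives the first steps beyond the scatter: a 3.1-fold higher number from compound 3 to compound 4 (0.50 log units; beyond the scatter), a 4.2-fold higher number from compound 2 to compound 4 (0.62 log units; beyond the scatter) and a 6.3-fold higher number from compound 1 to compound 4 (0.80 log units; beyond the scatter). The last of these has a four-membered ring on both sides, whereas the groups without chlorine, with four- or five-membered rings, all stay within the scatter of one another, so a change of ring size alone does not reproduce a step of this size among the compounds shown. No measurement on hand bears on the reason for the higher number.

No compound shown carries chlorine on a five-membered ring group, or has compound 4's group without chlorine, so the chlorine cannot yet be separated from the rest of the change. Going by these compounds, whether fluorine, methoxy or a nitrile in place of chlorine would give a similar number also remains open.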